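The source may report more compounds than this note shows. Statements on the series, on what has been measured and on what is new or still open speak of the compounds shown alone.

Working notes on the series.

Compound 2 `Cn1c(=O)c2c(nc(SCc3ccc(Cl)cc3)n2C)n(C)c1=O` is the stronger of the two measured compounds: in an assay on isolated protein for inhibition of Amine oxidase [flavin-containing] A (Homo sapiens), read by fluorescence (on this read-out higher numbers stand for weaker inhibition and lower numbers for stronger inhibition), compound 2 gives 2770 nM, the lowest of the two numbers. Its nearest neighbour is compound 1 `Cn1c(=O)c2c(nc(SCCOc3ccccc3)n2C)n(C)c1=O`, which in this assay gives 15500 nM. Among the measured compounds shown here, the single measured step, a 5.6-fold lower number from compound 1 to compound 2 (0.75 log units; beyond the scatter), swaps the group on the saturated chain carbon bound to the sulfur, so the only change known so far to move the number sits at the far end of that chain.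

Compound 3 `Cn1c(=O)c2c(nc(SCc3ccc(Br)cc3)n2C)n(C)c1=O` is not yet measured. It differs from compound 2 in one place: bromo in place of chloro on an aromatic carbon. For the measured compounds named here, no measured step exchanges one halogen for another on that ring, so the step from compound 2 to compound 1 gives only indirect guidance: it shows that the aryl end of the chain matters, but not how much a change from chloro to bromo weighs. The expectation for this assay is therefore a step of no more than the scatter, with a 1.1-fold lower number from compound 2 to compound 3 (0.04 log units; within the scatter) as the working guess, and the number for compound 3 is estimated at 2500 nM, within 1100 nM to 5500 nM.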

Compound 3, half-maximal inhibitory concentration: 2620 nM
Compound 3: the middle estimate sits 1.0-fold (0.02 log units) below what was measured; measured number inside the range.
By their numbers in this assay, from the lowest: compounds 3 and 2 (each within the scatter of the next); then compound 1.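

Working from the halogen exchange, in this assay bromo in place of chloro on the aromatic carbon, para to a large group, gives a 1.1-fold lower number from compound 2 to compound 3 (0.02 log units; within the scatter), so this position does not separate these two halogens in this assay. The step of a 5.9-fold lower number from compound 1 to compound 3 (0.77 log units; beyond the scatter) is close in size to a 5.6-fold lower number from compound 1 to compound 2 (0.75 log units; beyond the scatter), which shows that the gain over the phenoxymethyl end of compound 1 holds with either 4-chlorophenyl or 4-bromophenyl in place. No supporting measurement bears on why chloro and bromo read alike here.

The compounds shown leave open whether the position accepts groups other than these two halogens, such as hydrogen, methoxy, a nitrile or an amine, since two halogens alone cannot show how much the substituent there matters. They also leave open how far chain length alone counts, since the phenoxymethyl exchange replaces the whole end of the chain at once, and a longer saturated chain carrying 4-bromophenyl would be needed to separate the length of the chain from the nature of its aryl end.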